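The source may hold more compounds than are shown below. What is called first, only, known or untested is meant among the compounds shown, and "the series" means these compounds.

Working notes on the series. Compound 2 `COc1cc(C(=O)N/N=C/c2ccc(F)cc2)cc(OC)c1OC` gives 82.8% in a functional assay on PC-3 cells (Homo sapiens) for antiproliferative activity, read by MTT assay, tested at 5 uM (a higher number here means a stronger effect of the compound at the concentration tested, a lower number a weaker effect), and stands highest of the two numbers in hand; its nearest neighbour is compound 1 `COc1cc(C(=O)N/N=C/c2ccc(F)c(F)c2)cc(OC)c1OC`, which in this assay gives 43.7%. For the measured compounds named here, the only measured step is a number 39.1 percentage points higher from compound 1 to compound 2 (beyond the scatter), hydrogen in place of fluoro on an aromatic carbon. Compound 3 `COc1cc(C(=O)N/N=C/c2ccc(Cl)c(Cl)c2)cc(OC)c1OC` is not yet measured. Its change from compound 2 is 3,4-dichlorophenyl in place of 4-fluorophenyl on a carbon with a double bond to nitrogen. Going by the values given here, the one step that bears on this is the step from compound 1 to compound 2: it shows that taking the second fluoro off the ring went with a large rise, so putting a second halogen back on that ring, here as chloro, points the other way, and the exchange of fluoro for chloro at the remaining position is not covered by any measured pair. A fall in this assay beyond the scatter is therefore expected, though its size rests on one step with a different halogen; the expected step is a number 32.8 percentage points lower from compound 2 to compound 3 (beyond the scatter). Compound 3 is estimated at 50%, with a range from 25% to 75%.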

Compound 3, a percentage reported as inhibition, at one concentration (the size of the read-out at that concentration, not a potency): 31.6%
Compound 3: middle estimate off by 18.4 percentage points, on the high side; the measured number falls inside the stated range.
By their numbers in this assay, from the lowest: compound 3; then compound 1; then compound 2.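

In this assay, 3,4-dichlorophenyl in place of 4-fluorophenyl on the carbon with a double bond to nitrogen gives a number 51.2 percentage points lower from compound 2 to compound 3 (beyond the scatter), so the fall seen with the second fluoro in the earlier pair also appears when both halogens on the ring are chloro. The exchange of halogen, which no earlier pair covered, can now be read on a ring carrying two halogens: 3,4-dichlorophenyl in place of 3,4-difluorophenyl gives a number 12.1 percentage points lower from compound 1 to compound 3 (beyond the scatter), a modest fall beyond the scatter, and among these three compounds the two with a dihalogenated ring both stand below compound 2, with none going against this. Nothing measured on hand accounts for either fall.

The compounds shown do not separate the kind of halogen from the number of halogens at this position, since a phenyl ring carrying a single chloro does not appear among them. From the compounds shown here alone, the unsubstituted phenyl ring also does not appear, nor does a ring carrying a methoxy group or an amine in place of halogen, so it stays open whether any halogen is needed for the number seen with compound 2.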